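Pentyl Chain and Trifluoromethyl Combined on an Inactive Core

The source may hold more compounds than are shown below. What is called first, only, known or untested is meant among the compounds shown, and "the series" means these compounds.

Of the compounds shown here, three of one shared core have been tested in a functional assay on MDA-MB-231 cells (Homo sapiens) for inhibition, read by MTT assay, with a stated time of 24 h (on this read-out higher numbers stand for weaker inhibition and lower numbers for stronger inhibition), and each returned only a limit. Compound 1 `CCc1cc2ccccc2nc1-c1cc(-c2ccc(C)cc2)no1` gives only a limit of the assay, namely > 100000 nM in this measurement. Compound 2 `CCCCCc1cc2ccccc2nc1-c1cc(-c2ccc(C)cc2)no1` likewise gives only a limit, namely > 100000 nM in this measurement. Compound 3 `CCc1cc2ccccc2nc1-c1cc(-c2ccc(C(F)(F)F)cc2)no1` also gives only a limit, namely > 100000 nM in this measurement. Compound 3 therefore stands at the same limit as the two other measured compounds, and nothing separates it from them on the numbers shown. Both a step that the two limits leave unreadable from compound 1 to compound 2 and a step that the two limits leave unreadable from compound 1 to compound 3 remain without a size, as all three values sit at the limit of > 100000 nM in this assay, at which 3 of the 3 values shown sit, together.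

Compound 4 `CCCCCc1cc2ccccc2nc1-c1cc(-c2ccc(C(F)(F)F)cc2)no1` differs from compound 3 in one place: propyl in place of hydrogen on a saturated chain carbon, two bonds along the chain from an aromatic carbon. The same change on the shared core is the step that the two limits leave unreadable from compound 1 to compound 2, which gave no readable size. Compound 4 is accordingly expected to stay at the limit, with an estimate of 150000 nM and a range from 50000 nM to 500000 nM in this assay. The expected step that the limit leaves unreadable from compound 3 to compound 4 is thus estimated to show no change beyond the scatter.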

Compound 4, half-maximal inhibitory concentration: 22100 nM
Compound 4: the middle estimate sits 6.8-fold (0.83 log units) above what was measured, outside the stated range (below it).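

In this assay, propyl in place of hydrogen on a saturated chain carbon now gives an at least 4.5-fold lower number from compound 3 to compound 4 (0.65 log units; beyond the scatter), so a change that could not be read with methyl on the aromatic carbon can be read with trifluoromethyl there. Trifluoromethyl in place of methyl likewise gives an at least 4.5-fold lower number from compound 2 to compound 4 (0.65 log units; beyond the scatter), so this change can be read when the pentyl chain is present, though not with the ethyl chain. Only compound 4, which carries both groups, has a measured value rather than a limit, while compounds 1, 2 and 3 remain at: the limit of > 100000 nM in this assay, at which 3 of the 4 values shown sit.

As far as these compounds go, the true size of both steps stays open, since each starts from a limit. Also open, from the compounds shown here alone, is whether a longer chain than pentyl or an amine in its place, or a nitrile in place of trifluoromethyl, would lower the number further.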